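A few compounds are considered here, and "the series" means these few. Any claim that something is new, unique, unknown or untested is made for them only; others in the source may bear on it.

Of the compounds shown here, three have so far been tested in an ADME assay on RAW264.7 cells (Mus musculus) for cytotoxicity, read by MTT assay, with a stated time of 48 h, tested at 100 uM; on this read-out higher numbers stand for more inhibition at the one concentration tested (going by the name of the read-out) and lower numbers for less inhibition. Compound 1 `O=c1ccc2ncc(F)cc2n1CCN1CCC(NC(=S)NCc2ccc(Cl)cc2)CC1` gives 43.7%, compound 2 `COc1ccc(CNC(=O)NC2CCN(CCn3c(=O)ccc4ncc(OC)cc43)CC2)cc1` gives 39.5%, and compound 3 `COc1ccc(CNC(=S)NC2CCN(CCn3c(=O)ccc4ncc(F)cc43)CC2)cc1` gives 41.3% in this assay. Compound 3 and compound 1 differ by chloro in place of methoxy on an aromatic carbon, and in this assay that change made a step of a number 2.4 percentage points higher from compound 3 to compound 1 (within the scatter). Compound 4 `COc1cnc2ccc(=O)n(CCN3CCC(NC(=O)NCc4ccc(Cl)cc4)CC3)c2c1` has not yet been measured; it differs from compound 2 by chloro in place of methoxy on an aromatic carbon, the same change at the same place. The difference between the cores of compound 2 and compound 3 is not broken down here. Because the earlier step was a number 2.4 percentage points higher from compound 3 to compound 1 (within the scatter), the change is expected to make a step of a number 2 percentage points higher from compound 2 to compound 4 (within the scatter) in this assay. Compound 4 is therefore estimated to give 41.5%, with an expected range from 32% to 51%.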

Compound 4, a percentage reported as inhibition, at one concentration (the size of the read-out at that concentration, not a potency): 40.9%
Estimate against measurement, compound 4: 0.6 percentage points above; the measured number falls inside the stated range.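

In this assay, the change from 4-methoxybenzyl to 4-chlorobenzyl gave a number 1.4 percentage points higher from compound 2 to compound 4 (within the scatter). Set beside the earlier step on the other core, the new step agrees with it: the same change on two cores in this assay, a number 2.4 percentage points higher (within the scatter) from compound 3 to compound 1 and a number 1.4 percentage points higher (within the scatter) from compound 2 to compound 4, 1 percentage points apart, within the scatter of two such steps. Across these two cores the change therefore carries over without a visible difference, but neither step stands clear of the scatter, so this shows only that the change does little in both pairs, not that it would behave the same way on any further core.

The compounds shown leave open whether an amine or a carboxylic acid on the same aromatic carbon would shift the number beyond the scatter. They also leave open what a longer chain in place of the 4-chlorobenzyl group would do.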